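A few compounds are considered here, and "the series" means these few. Any claim that something is new, unique, unknown or untested is made for them only; others in the source may bear on it.

Compound 1 `COc1cc(OC)cc(-n2c(-c3ccccc3)nc(C)c2C)c1` is one of two measured compounds. In a functional assay, read by spectrophotometry, with a stated time of 30 min, tested at 10 uM (on this read-out lower numbers stand for a weaker effect and higher numbers for a stronger effect at the one concentration tested), compound 1 gives 17.2%, and compound 2 `COc1ccc(-n2c(-c3ccccc3)nc(C)c2C)cc1` gives 14.1% in this assay, the two figures lying within the scatter of each other, so neither can be set apart from the other. Compound 3 `COc1cc(OC)cc(-n2c(-c3ccc(F)cc3)nc(C)c2C)c1` differs from compound 1 by fluoro in place of hydrogen on an aromatic carbon. For the measured compounds named here, with no measured pair showing the effect of this change, a step no larger than the scatter is expected, in no favoured direction, namely a number 0.8 percentage points higher from compound 1 to compound 3 (within the scatter). Compound 3 is accordingly estimated at 18%, between 8% and 30%.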

Compound 3, a percentage reported as activity, at one concentration (the size of the read-out at that concentration, not a potency): 12.1%
Compound 3: middle estimate off by 5.9 percentage points, on the high side; the range from low to high includes it.
By their numbers in this assay, from the lowest: compounds 3, 2 and 1 (each within the scatter of the next).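

The change from phenyl to 4-fluorophenyl on the core of compound 1 now has a measured step in this assay, namely a number 5.1 percentage points lower from compound 1 to compound 3 (within the scatter). Fluoro, para to a large group, therefore cannot be set apart from hydrogen at this position on this read-out. Nothing available here bears on the reason for this result. As far as these compounds go, whether chloro, an amine or a carboxylic acid in the same place would move the figure beyond the scatter stays open. So does the effect of fluoro on another carbon of that ring.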